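This account rests on a few compounds, and the source may have more. Where it says the series, first, only, none or still open, it means among the compounds named here.

Values in a functional assay on HeLa cells (Homo sapiens) for inhibition, with a stated time of 72 h; on this read-out higher numbers stand for weaker inhibition and lower numbers for stronger inhibition:
- compound 1, `NC1CCC(Nc2nc(NCc3ccc(-c4cccc(F)c4)cc3)c3ncn(C4CCCC4)c3n2)CC1`: 445 nM
- compound 2, `NC1CCC(Nc2nc(NCc3ccc(-c4ccco4)cc3)c3ncn(C4CCCC4)c3n2)CC1`: 71 nM
- compound 3, `CC(C)(O)CNc1nc(NCc2ccc(-c3ccco3)cc2)c2ncn(C3CCCC3)c2n1`: 14800 nM
- compound 4, `NC1CCC(Nc2nc(NCc3ccc(-c4ccco4)nc3)c3ncn(C4CCCC4)c3n2)CC1`: not yet measured

Among the three measured compounds, compound 2 has the lowest number, at 71 nM. The next change is 6-(furan-2-yl)pyridin-3-yl in place of 4-(furan-2-yl)phenyl on a saturated chain carbon bound to a nitrogen on an aromatic ring.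

The closest measured evidence is a 6.3-fold lower number from compound 1 to compound 2 (0.80 log units; beyond the scatter), a modest step from a change within the same group. The large 210-fold higher number from compound 2 to compound 3 (2.32 log units; beyond the scatter) comes from a change elsewhere, at the 4-aminocyclohexyl group, and bears on this question only weakly. Among the compounds with values here, no measured pair shows the effect of replacing a six-membered aromatic ring of carbon only with one containing a hetero atom, so the direction remains uncertain.

In this assay, a small rise is expected, probably no larger than the modest step above. The expected change is a 1.7-fold higher number from compound 2 to compound 4 (0.23 log units; within the scatter). For compound 4 the estimate is 120 nM, with an expected range of 40 nM to 360 nM.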

Compound 4, half-maximal inhibitory concentration: 30 nM
Compound 4: the middle estimate sits 4.0-fold (0.60 log units) above what was measured, outside the stated range (below it).
By their numbers in this assay, from the lowest: compound 4; then compound 2; then compound 1; then compound 3.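

Read in this assay the exchange of 4-(furan-2-yl)phenyl for 6-(furan-2-yl)pyridin-3-yl gives a 2.4-fold lower number from compound 2 to compound 4 (0.37 log units; beyond the scatter) and this is the first measured pair in which a six-membered aromatic ring of carbon only gives way to one with a hetero atom. With the 4-aminocyclohexyl and furan-2-yl groups held constant, the number at this position moves down rather than up, so the added ring nitrogen is accepted here. No measurement at hand accounts for the step.

Only one such ring and one terminal ring are shown, so it remains open whether a 6-(3-fluorophenyl)pyridin-3-yl group would lower the number relative to compound 1 in the same way. A 6-(thiophen-2-yl)pyridin-3-yl group or a pyrimidin-5-yl ring carrying the furan-2-yl group would test how far the trend extends.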